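The source may report more compounds than this note shows. Statements on the series, on what has been measured and on what is new or still open speak of the compounds shown alone.

Measured so far:
- Compound 1, `CCc1nn(CCCN2CCN(c3ccc(C)cc3)CC2)c(=O)c(N)c1C(C)=O`: 41%
- Compound 2, `CCC(=O)c1c(C)nn(CCCN2CCN(c3ccc(C)cc3)CC2)c(=O)c1N`: 29%
- Compound 3, `Cc1c(C#N)c(-c2ccccc2)nn1CCCN1CCN(c2cccc(Cl)c2)CC1`: 23%

In a functional assay on the whole organism (Abdomen, strain Swiss) for inhibition, with Mus musculus as the target, with stated times of 30 min, 10 min and 5 min, at a dose of 40 mg/kg by the oral route (a higher number here means a stronger effect of the compound at the dose given, a lower number a weaker effect), compound 3 gives the lowest of the three numbers. Compound 2 sits higher by a gap that is within the scatter, so the two cannot be told apart; compound 1 sits higher by a gap that is beyond the scatter.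

Compound 4, `Cc1ccc(N2CCN(CCCn3nc(-c4ccccc4)c(C#N)c3C)CC2)cc1`, keeps the core of compound 3 and changes one group:

4-methylphenyl in place of 3-chlorophenyl on an amine nitrogen in a ring

Within the data shown here, no pair of measured compounds that differ in only this way exists, so the step has no precedent here. Compounds 1 and 2 carry the entering group, but on a different core, so their values do not speak to this change. The step from compound 3 to compound 4 in this assay is expected to be a number 5 percentage points higher from compound 3 to compound 4 (within the scatter), not beyond the scatter. Compound 4 is estimated at 28%, with a range from 10% to 48%.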

Compound 4, a percentage reported as inhibition, in the whole organism at one dose (the size of the read-out at that dose, not a potency): 30%
Estimate against measurement, compound 4: 2 percentage points below; low and high end bracket the measured number.
By their numbers in this assay, from the lowest: compounds 3, 2 and 4 (each within the scatter of the next); then compound 1.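

Among these compounds, compounds 3 and 4 are the first pair here that differ in one place only, so the group on the amine nitrogen in the ring can be compared directly on a shared core. In this assay the exchange of 3-chlorophenyl for 4-methylphenyl gives a number 7 percentage points higher from compound 3 to compound 4 (within the scatter) and so leaves the two compounds indistinguishable. Nothing measured here offers a reason for this result. On these data alone, whether a plain phenyl or a methoxyphenyl on this nitrogen would give a clearly different number remains open. So does whether the same exchange would behave alike on the core of compound 1.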